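Acylguanidine Sodium/Hydrogen Exchanger Inhibitors: Aryl Ether Variation

The source may hold more compounds than are shown below. What is called first, only, known or untested is meant among the compounds shown, and "the series" means these compounds.

Measured compounds:
compound 1, `CS(=O)(=O)c1cc(C(=O)N=C(N)N)ccc1-n1cccn1`, 160 nM
compound 2, `Cc1ccc(C(=O)N=C(N)N)cc1S(C)(=O)=O`, 210 nM

In a functional assay for inhibition of sodium/hydrogen exchanger (Oryctolagus cuniculus) (on this read-out higher numbers stand for weaker inhibition and lower numbers for stronger inhibition), compound 2 gives 210 nM, the highest of the two numbers recorded, with compound 1 nearest at a 1.3-fold higher number from compound 1 to compound 2 (0.12 log units; within the scatter).

Compound 3, `CS(=O)(=O)c1cc(C(=O)N=C(N)N)ccc1Oc1cncc(Cl)c1`, has not yet been measured in this assay. It differs from compound 2 in one place: (5-chloropyridin-3-yl)oxy in place of methyl on an aromatic carbon.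

Among the measured compounds shown here, only one measured step bears on this change, the one between compound 1 and compound 2, in which a 1H-pyrazol-1-yl group gave way to a methyl group at the same aromatic carbon, and that step was a 1.3-fold higher number from compound 1 to compound 2 (0.12 log units; within the scatter). The change from compound 2 to compound 3 again swaps the methyl at that carbon for a ring-bearing group, this time a (5-chloropyridin-3-yl)oxy group. On that single precedent, no step beyond the scatter is expected in this assay, in either direction, although the new group is larger and unlike any group already measured, so the expectation is held loosely.

Compound 3 is therefore expected to give about 200 nM, with a range from 70 nM to 600 nM, meaning an estimated 1.1-fold lower number from compound 2 to compound 3 (0.02 log units; within the scatter).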

Compound 3, half-maximal inhibitory concentration: 75 nM
For compound 3 the middle estimate is 2.7-fold (0.43 log units) above the measured one, and the stated range covers the measured number.
By their numbers in this assay, from the lowest: compound 3; then compounds 1 and 2 (each within the scatter of the next).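

Until now, the aromatic carbon ortho to the methylsulfonyl group had shown no step beyond the scatter in this assay, the only comparison being a 1.3-fold higher number from compound 1 to compound 2 (0.12 log units; within the scatter) on exchanging 1H-pyrazol-1-yl for methyl. The (5-chloropyridin-3-yl)oxy group gives the first movement beyond the scatter at this carbon, with a 2.8-fold lower number from compound 2 to compound 3 (0.45 log units; beyond the scatter) against methyl and a 2.1-fold lower number from compound 1 to compound 3 (0.33 log units; beyond the scatter) against 1H-pyrazol-1-yl, so the read-out does respond to what is placed there, though both steps are modest and the two ring-bearing groups are not interchangeable at this position. Nothing in the material shown accounts for this stronger inhibition.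

The compounds shown cannot separate the contributions of the ether oxygen, the ring nitrogen and the chlorine, all of which enter together in this change, so a plain phenoxy group or a 5-chloropyridin-3-yl group joined directly to the carbon would be the telling comparisons. On these data alone, it also remains open how a small group such as an amine or a methoxy group would read at this carbon.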